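Oxime series: methyl for methoxy, compound 3 to compound 4

The source may hold more compounds than are shown below. What is called first, only, known or untested is meant among the compounds shown, and "the series" means these compounds.

Measured in a functional assay (Mus musculus, strain Balb/c) for inhibition, read by ELISA, with a stated time of 72 h; a higher number here means a weaker inhibitor, a lower number a stronger inhibitor:
compound 1 `COc1ccc(C(/C=C/c2ccc(F)cc2)=N/O)cc1` gives 11000 nM
compound 2 `COc1ccc(C(/C=C/c2ccc(Br)cc2)=N/O)cc1` gives 13900 nM
compound 3 `COc1ccc(/C=C/C(=N\O)c2ccc(OC)cc2)cc1` gives 12300 nM

Compound 3 stands second highest of the three numbers, with compound 1 nearest and compound 2 furthest, both within the scatter of it. Compound 4 `COc1ccc(/C=C/C(=N\O)c2ccc(C)cc2)cc1` differs from compound 3 as follows: methyl in place of methoxy on an aromatic carbon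

The measured steps of a 1.3-fold higher number from compound 1 to compound 2 (0.10 log units; within the scatter), a 1.1-fold higher number from compound 1 to compound 3 (0.05 log units; within the scatter) and a 1.1-fold lower number from compound 2 to compound 3 (0.05 log units; within the scatter) all exchange one group on an aromatic carbon and all lie within the scatter, but none exchanges methoxy for methyl, so none bears directly on this change. With no step beyond the scatter anywhere in the series, no step beyond the scatter is expected in this assay either. Compound 4 is estimated at 12500 nM, between 6000 nM and 26000 nM, which means an expected step of a 1.0-fold higher number from compound 3 to compound 4 (0.01 log units; within the scatter).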

Compound 4, half-maximal inhibitory concentration: 6240 nM
Estimate against measurement, compound 4: 2.0-fold (0.30 log units) above; measured number inside the range.
By their numbers in this assay, from the lowest: compounds 4, 1, 3 and 2 (each within the scatter of the next, the first and the last beyond it).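

In this assay methyl in place of methoxy gives a 2.0-fold lower number from compound 3 to compound 4 (0.29 log units; within the scatter) and is the first step shown at this position, on the aromatic ring that the earlier exchanges left untouched. The exchange removes one heavy atom and the one hydrogen-bond acceptor of methoxy, yet the step lies within the scatter, so the shown data separate neither group here. No measurement available gives a reason for this step.

On these data alone, whether an amine, a carboxylic acid or a longer chain at this position would give a step beyond the scatter remains open. Also open, as far as these compounds go, is whether methyl here would give a similar step with fluoro or bromo on the other ring.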